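This account rests on a few compounds, and the source may have more. Where it says the series, first, only, none or still open, it means among the compounds named here.

Measured so far:
- compound 1, `CN1CCN(CC(=O)Nc2ccc(-c3nc4cc(Cl)c(Cl)cc4[nH]3)cc2)CC1`, 41000 nM in an ADME assay on BHK cells (Mesocricetus auratus) for cytotoxicity, read by MTT assay, with a stated time of 96 h; a lower number here means that less compound is tolerated, a higher number that more compound is tolerated
- compound 2, `CN1CCN(CC(=O)Nc2ccc(-c3nc4cc(C(F)(F)F)ccc4n3C)cc2)CC1`, 16000 nM
- compound 3, `Cn1c(-c2ccc(NC(=O)CN3CCCC3)cc2)nc2cc(C(F)(F)F)ccc21`, 27000 nM

These three compounds share a core and differ in the amine at the end of the side chain and in the substituents on the core. Their numbers lie close together: compound 3 sits within the scatter of compound 1 and within the scatter of compound 2, so none of the three can be called better or worse tolerated than the others.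

Compound 4, `CCN(CC)CC(=O)Nc1ccc(-c2nc3cc(C(F)(F)F)ccc3n2C)cc1`, has not yet been measured. It differs from compound 3 in one place: diethylamino in place of pyrrolidin-1-yl on a saturated chain carbon bound to a carbonyl carbon. Among the compounds with values here, the only measured step that changes the same amine, a 1.7-fold higher number from compound 2 to compound 3 (0.23 log units; within the scatter), stayed within the scatter. Within the data shown here, the one comparable step therefore gives no reason to expect a move beyond the scatter for compound 4, and the step of no change at the digits printed from compound 3 to compound 4 (within the scatter) is expected to be small. Compound 4 is expected to give about 27000 nM, with a likely range from 12000 nM to 55000 nM.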

Compound 4, half-maximal cytotoxic concentration: 16000 nM
Compound 4: the middle estimate sits 1.7-fold (0.23 log units) above what was measured; the range from low to high includes it.
By their numbers in this assay, from the lowest: compounds 2, 4, 3 and 1 (each within the scatter of the next, the first and the last beyond it).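

With compound 4, this place on a saturated chain carbon bound to a carbonyl carbon now holds three different amines on the same core, and in this assay all the steps between them stay within the scatter. Going from a ring to no ring, with the same count of heavy atoms, gives a 1.7-fold lower number from compound 3 to compound 4 (0.23 log units; within the scatter) and the change from 4-methylpiperazin-1-yl to diethylamino gives no change at the digits printed from compound 2 to compound 4 (within the scatter) as its result. Among these three amines, then, neither the ring nor its absence separates the compounds in how much is tolerated.

As far as these compounds go, whether a morpholin-4-yl group, a carboxylic acid or a longer chain at this place would move the number beyond the scatter stays open. Nothing shown here bears on what lies behind these numbers.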